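Benzyl substituent variation: compound 3 to compound 4

A few compounds are considered here, and "the series" means these few. Any claim that something is new, unique, unknown or untested is made for them only; others in the source may bear on it.

Measured in an assay for inhibition of MAP kinase-interacting serine/threonine-protein kinase 2 (Homo sapiens), read by luminescence and ADP-Glo, with a stated time of 2 h; a lower number here means a stronger inhibitor, a higher number a weaker inhibitor:
compound 1 `O=c1ccc(-c2ccc3cn[nH]c3c2)cn1Cc1ccccc1C(F)(F)F` gives 100 nM
compound 2 `Nc1cccc(Cn2cc(-c3ccc4cn[nH]c4c3)ccc2=O)c1` gives 84 nM
compound 3 `O=c1ccc(-c2ccc3cn[nH]c3c2)cn1Cc1cccc(Cl)c1` gives 40 nM

Compound 3 holds the lowest number of the three, separated from compound 2 and from compound 1 by steps beyond the scatter. For the measured compounds named here, the one single-place step recorded, a 2.1-fold lower number from compound 2 to compound 3 (0.32 log units; beyond the scatter), is a modest one.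

Compound 4 `O=c1ccc(-c2ccc3cn[nH]c3c2)cn1Cc1ccccc1F` differs from compound 3 in one place: 2-fluorophenyl in place of 3-chlorophenyl on a saturated chain carbon bound to an aromatic nitrogen. Going by the values given here, no recorded step covers this exchange. The step from compound 2 to compound 3 shows that a substituent swap on this benzyl ring moves this assay only modestly. Compound 1 carries a different substituted benzyl and gives 100 nM, while compound 3 gives 40 nM; the whole span of the series is small. Compound 4 is therefore expected to land close to compound 3, with the expected step of a 2.0-fold higher number from compound 3 to compound 4 (0.30 log units; within the scatter) small and, if anything, toward a higher number. The estimate for compound 4 in this assay is 80 nM, with a range from 35 nM to 180 nM.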

Compound 4, half-maximal inhibitory concentration: 37 nM
Estimate against measurement, compound 4: 2.2-fold (0.33 log units) above; low and high end bracket the measured number.
By their numbers in this assay, from the lowest: compounds 4 and 3 (each within the scatter of the next); then compounds 2 and 1 (each within the scatter of the next).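

In this assay, 2-fluorophenyl in place of 3-chlorophenyl on a saturated chain carbon bound to an aromatic nitrogen gives a 1.1-fold lower number from compound 3 to compound 4 (0.03 log units; within the scatter) and so leaves the two compounds unresolved, even though both the halogen and its printed ring number change in this one exchange. The other two exchanges are modest but beyond the scatter: 2-fluorophenyl in place of 3-aminophenyl gives a 2.3-fold lower number from compound 2 to compound 4 (0.36 log units; beyond the scatter) and fluoro in place of trifluoromethyl on an aromatic carbon gives a 2.7-fold lower number from compound 1 to compound 4 (0.43 log units; beyond the scatter) in this series. No available evidence accounts for these differences.

From the compounds shown here alone, because both features change together, the separate contributions of the halogen and its ring number remain open, and 2-chlorophenyl and 3-fluorophenyl would separate them. Also open, going by these compounds, is how a carboxylic acid on the benzyl ring, or a longer chain in place of the benzyl carbon, would read.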